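The compounds below may be only part of what the source reports. "The series", "measured", "known", "first", "only" and "open" are said of these compounds alone.

Series so far in a functional assay on A549 cells (Homo sapiens) for inhibition, read by colorimetric assay and MTT assay, with a stated time of 72 h; a lower number here means a stronger inhibitor, a higher number a weaker inhibitor
Compound 1 `C=CCCCCOc1ccccc1-c1cnc(OCCC=C)n1C` gives 9000 nM
Compound 2 `C=CCCCCOc1ccccc1-c1cnc(OCCCCC=C)n1C` gives 7000 nM
Compound 3 `C=CCCCCOc1ccccc1-c1cnc(OC)n1C` gives 80000 nM

Compound 3 has the highest number of the three. The next step leads to compound 4 `C=CCCCCOc1ccccc1-c1cnc(S(=O)(=O)c2ccccc2)n1C` with phenylsulfonyl in place of methoxy on an aromatic carbon, between two ring nitrogen atoms phenylsulfonyl in place of methoxy on an aromatic carbon as the counted change. Two measured steps change the group at this carbon: an 8.9-fold higher number from compound 1 to compound 3 (0.95 log units; beyond the scatter) and an 11-fold higher number from compound 2 to compound 3 (1.06 log units; beyond the scatter) both end at the methoxy compound, so the longer chains sit lower. The step of a 1.3-fold lower number from compound 1 to compound 2 (0.11 log units; within the scatter) separates nothing. Neither chain compound carries a sulfonyl or a second aromatic ring, so the transfer is loose, and a lower number of smaller size is expected. The expected step is a 5.3-fold lower number from compound 3 to compound 4 (0.73 log units; beyond the scatter) on this estimate. For compound 4 the estimated value is 15000 nM with an expected range of 4000 nM to 60000 nM in this assay here.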

Compound 4, half-maximal inhibitory concentration: 38000 nM
For compound 4 the middle estimate is 2.5-fold (0.40 log units) below the measured one, within the range that was stated.
By their numbers in this assay, from the lowest: compounds 2 and 1 (each within the scatter of the next); then compound 4; then compound 3.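

In this assay, the aromatic carbon between two ring nitrogen atoms accepts phenylsulfonyl with only a small gain over methoxy, a 2.1-fold lower number from compound 3 to compound 4 (0.32 log units; beyond the scatter). Phenylsulfonyl still falls short of both oxygen-linked chains, a 5.4-fold higher number from compound 2 to compound 4 (0.73 log units; beyond the scatter) and a 4.2-fold higher number from compound 1 to compound 4 (0.63 log units; beyond the scatter), so at this position the alkenyl ethers keep the lowest numbers among the four compounds. Nothing measured here explains these steps.

Going by these compounds, whether the step from methoxy follows the sulfonyl or the added phenyl ring stays open. A methylsulfonyl group or a plain phenyl group at this carbon would separate the two.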